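Swapping the Aryl Group on a Cinnamate Ester

The source may hold more compounds than are shown below. What is called first, only, known or untested is meant among the compounds shown, and "the series" means these compounds.

Measured so far:
compound 1, `COc1cc(OC)c(OC)cc1/C=C/COC(=O)/C=C/c1cccc(Br)c1`, 100% 
compound 2, `COc1cc(OC)c(OC)cc1/C=C/COC(=O)/C=C/c1ccccc1Cl`, 100% 

In a functional assay on the whole organism (strain Kunming) with Mus musculus as the target, with a stated time of 0.5 h, at a dose of 100 mg/kg by the intraperitoneal route (a lower number here means a stronger effect, a higher number a weaker effect of the compound at the dose given), compound 2 stands level with compound 1 at the digits shown, and the step of no change at the digits printed from compound 1 to compound 2 (within the scatter) lies within the scatter. Compound 3, `COc1ccc(/C=C/C(=O)OC/C=C/c2cc(OC)c(OC)cc2OC)cc1`, differs from compound 2 by 4-methoxyphenyl in place of 2-chlorophenyl on a double-bonded chain carbon bound to a double-bonded chain carbon. Going by the values given here, only one measured step touches this position, and it showed nothing beyond the scatter, so a swap of the aryl group at this place gave no visible change there. On these data alone, a similar outcome is expected here, though the methoxy-bearing group is untested and the value cannot rise further. The estimate for compound 3 is 90%, between 65% and 100%, meaning an expected step of a number 10 percentage points lower from compound 2 to compound 3 (within the scatter).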

Compound 3, a percentage reported as activity, at one dose (the size of the read-out at that dose, not a potency): 100%
Compound 3: the middle estimate sits 10 percentage points below what was measured; low and high end bracket the measured number.
By their numbers in this assay, from the lowest: compounds 1, 2 and 3 (each within the scatter of the next).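

In this assay, the aryl group has now been swapped for a third kind, and the reading holds: there is no change at the digits printed from compound 2 to compound 3 (within the scatter), and likewise no change at the digits printed from compound 1 to compound 3 (within the scatter). Thus 4-methoxyphenyl, which adds one hydrogen-bond acceptor that 2-chlorophenyl does not have, reads the same as both halogen-bearing groups at this place. No supporting data are available to explain this outcome. Still open, on these data alone, is whether an amine or a carboxylic acid at this place would give a lower number. Changes to the shared core also remain open.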